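Three Amine Substituents on One Core, a Fourth Expected

The source may report more compounds than this note shows. Statements on the series, on what has been measured and on what is new or still open speak of the compounds shown alone.

Compound 1, `CN1CCC(c2ccc(OCc3ccccc3)c(C(=O)Nc3ccnnc3)c2)CC1`, gives 20 nM in an assay on Sf9 cells for inhibition of Leucine-rich repeat serine/threonine-protein kinase 2 (Homo sapiens), read by TR-FRET, with stated times of 30 min and 2 h; on this read-out higher numbers stand for weaker inhibition and lower numbers for stronger inhibition.
Compound 2, `C[C@@H]1CN(c2ccc(OCc3ccccc3)c(C(=O)Nc3ccnnc3)c2)C[C@H](C)O1`, gives 20 nM in this assay.
Compound 3, `CN1CCN(c2ccc(OCc3ccccc3)c(C(=O)Nc3ccnnc3)c2)CC1`, gives 12.6 nM in this assay.

Compound 3 gives the lowest number of the three, yet both of its neighbours sit within the usual scatter of it: a 1.6-fold lower number from compound 1 to compound 3 (0.20 log units; within the scatter) and a 1.6-fold lower number from compound 2 to compound 3 (0.20 log units; within the scatter). Likewise no change at the digits printed from compound 1 to compound 2 (within the scatter). The three compounds share one core and differ only in the saturated amine group on the aromatic carbon, and none of these exchanges moved the number beyond the scatter.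

Compound 4, `O=C(Nc1ccnnc1)c1cc(N2CCC(CO)CC2)ccc1OCc1ccccc1`, has not yet been measured in this assay. Its change from compound 3 is 4-(hydroxymethyl)piperidin-1-yl in place of 4-methylpiperazin-1-yl on an aromatic carbon. The two steps that bear on it, from compound 1 to compound 3 and from compound 2 to compound 3, each replaced one six-membered saturated amine with another at the same aromatic carbon and stayed within the scatter. On that basis the step from compound 3 to compound 4 is expected to be a 1.3-fold higher number from compound 3 to compound 4 (0.10 log units; within the scatter), no larger than the scatter. Compound 4 is therefore estimated to give 16 nM in this assay. The expected range for compound 4 runs from 6 nM to 45 nM.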

Compound 4, half-maximal inhibitory concentration: 20 nM
Compound 4: the middle estimate sits 1.3-fold (0.10 log units) below what was measured; the range from low to high includes it.
By their numbers in this assay, from the lowest: compounds 3, 1, 2 and 4 (each within the scatter of the next).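

Compound 4 puts at this position, on the aromatic carbon para to a benzyloxy group, a ring with one hetero atom and a hydroxymethyl group, which brings a hydrogen-bond donor that the departing 4-methylpiperazin-1-yl group does not have. In this assay, within the data shown here, this exchange is read as a 1.6-fold higher number from compound 3 to compound 4 (0.20 log units; within the scatter) while the comparisons with the other two amines are read as no change at the digits printed from compound 2 to compound 4 (within the scatter) and no change at the digits printed from compound 1 to compound 4 (within the scatter) so that no step among the four compounds leaves the scatter. The position has therefore now taken a group carrying a hydroxyl as well as the three earlier saturated rings, with all four numbers lying too close together to be ranked.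

The compounds shown leave open whether a carboxylic acid, a primary amine or a longer chain ending in a hydroxyl at this same aromatic carbon would move the number beyond the scatter, or whether an open-chain amine in place of the six-membered ring would do so. No measurement given here speaks to why these exchanges all stay within the scatter.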